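From Trifluoromethoxy to Chloro in Compound 4

The compounds below may be only part of what the source reports. "The series", "measured", "known", "first", "only" and "open" are said of these compounds alone.

- compound 1 `O=S1(=O)C=Cc2ccc(Nc3ccc(Cl)cc3)cc21` gives 4440 nM here
- compound 2 `O=S1(=O)C=Cc2ccc(Nc3cccc(OC(F)(F)F)c3)cc21` gives 1980 nM here
- compound 3 `O=S1(=O)C=Cc2cccc(Nc3ccc(OC(F)(F)F)cc3)c21` gives 2380 nM here

These values come from a functional assay on HCT-116 cells (Homo sapiens) for antiproliferative activity, read by MTT assay, with a stated time of 72 h (a higher number here means a weaker inhibitor, a lower number a stronger inhibitor), and they frame the next comparison. Compound 3 lies within the usual scatter of both compound 2 and compound 1, so it cannot be separated from either of them.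

The unmeasured compound 4 `O=S1(=O)C=Cc2cccc(Nc3ccc(Cl)cc3)c21` carries chloro in place of trifluoromethoxy on an aromatic carbon, para to a large group chloro in place of trifluoromethoxy on an aromatic carbon and otherwise matches compound 3. Within the data shown here, no pair of measured compounds shows this change alone. Among the measured compounds shown here, the closest guide is compound 1, the only measured compound with chloro, at 4440 nM in the same test, although it also differs from compound 3 elsewhere. In this assay the expected change is a 1.3-fold higher number from compound 3 to compound 4 (0.13 log units; within the scatter) and that is a modest move toward a higher number, probably within the scatter. For compound 4 the estimated value is 3200 nM with a range of 1400 nM to 7500 nM expected.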

Compound 4, half-maximal inhibitory concentration: 260 nM
The estimate for compound 4 lay 12-fold (1.09 log units) above the measured number; the whole stated range lies above it.
By their numbers in this assay, from the lowest: compound 4; then compounds 2, 3 and 1 (each within the scatter of the next, the first and the last beyond it).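

In this assay, chloro in place of trifluoromethoxy on this aromatic carbon, para to a large group, gives a 9.2-fold lower number from compound 3 to compound 4 (0.96 log units; beyond the scatter), which is beyond the scatter and the only single change that can be read among these compounds. Chloro alone does not guarantee such a low number: differing from compound 4 elsewhere on the shared core, compound 1 also carries chloro and gives 4440 nM, so the result depends on the setting of the group as well as on the group itself. Nothing measured here explains this step.

The compounds shown leave open how fluoro, bromo, methyl or an amine on the same carbon would compare with chloro. They also leave open whether swapping trifluoromethoxy for chloro would give a step of similar size on the core of compound 1.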